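Changing the benzyl ring on the amide of compound 2

The source may report more compounds than this note shows. Statements on the series, on what has been measured and on what is new or still open speak of the compounds shown alone.

Compound 2 `O=C(O)C[C@H](O)C[C@H](O)CCn1c(-c2ccc(F)cc2)nc(C(=O)NCc2ccccc2F)c1C1CC1` was tested in an assay on microsomes from liver for inhibition of 3-hydroxy-3-methylglutaryl-coenzyme A reductase (Rattus norvegicus), read by scintillation counting, with stated times of 0.5 h and 0.75 h (a higher number here means a weaker inhibitor, a lower number a stronger inhibitor), where compound 2 gives 1.5 nM, the lowest of the two numbers measured. Its nearest neighbour, compound 1 `Cc1ccccc1CNC(=O)c1nc(-c2ccc(F)cc2)n(CC[C@@H](O)C[C@@H](O)CC(=O)O)c1C1CC1`, gives 4.9 nM in this assay; the step between them, a 3.3-fold lower number from compound 1 to compound 2 (0.51 log units; beyond the scatter), accompanies a fluoro in place of methyl on an aromatic carbon. Compound 3 `COc1ccc(CNC(=O)c2nc(-c3ccc(F)cc3)n(CC[C@@H](O)C[C@@H](O)CC(=O)O)c2C2CC2)cc1F` carries the change (3-fluoro-4-methoxyphenyl in place of 2-fluorophenyl on a saturated chain carbon bound to an amide-type nitrogen). For the measured compounds named here, only the step from compound 1 to compound 2 bears on this, and it shows that swapping a substituent on this ring shifts the number modestly. Going by the values given here, the new change is larger than that step, bringing in a methoxy group as well, and the data hold no step that speaks to it directly. For compound 3 a shift of similar size, with no clear direction, is expected a 2.0-fold higher number from compound 2 to compound 3 (0.30 log units; within the scatter). Compound 3 is therefore estimated at 3 nM, within 1 nM to 10 nM.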

Compound 3, half-maximal inhibitory concentration: 3.7 nM
Estimate against measurement, compound 3: 1.2-fold (0.09 log units) below; low and high end bracket the measured number.
By their numbers in this assay, from the lowest: compound 2; then compounds 3 and 1 (each within the scatter of the next).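

Replacing 2-fluorophenyl with the larger 3-fluoro-4-methoxyphenyl on a saturated chain carbon bound to an amide-type nitrogen gives a 2.5-fold higher number from compound 2 to compound 3 (0.39 log units; beyond the scatter) in this assay, so this position still holds a low number with a second ring substituent and one hydrogen-bond acceptor added, at a modest loss. Measured against the 2-methylphenyl group, the same ring gives a 1.3-fold lower number from compound 1 to compound 3 (0.12 log units; within the scatter) and so sets no order between these two compounds, while compound 2 remains clearly the lowest of the three. Nothing available explains these shifts.

On these data alone, what stays open is whether the loss goes with the methoxy group or with the new place of the fluoro, which a 3-fluorophenyl group could separate. As far as these compounds go, how this ring would read with an amine or a carboxylic acid on it also remains open.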